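A few compounds are considered here, and "the series" means these few. Any claim that something is new, unique, unknown or untested is made for them only; others in the source may bear on it.

Of the compounds shown here, three share one core and have been measured in an ADME assay on WI-38 cells (Homo sapiens) for cytotoxicity, read by MTT assay, with a stated time of 72 h; a higher number here means a weaker inhibitor, a lower number a stronger inhibitor. Compound 1 `Cn1ncnc1-c1cc(Oc2ccc(NC(=O)Nc3cccc(C(F)(F)F)c3)cc2F)ccn1` gives 22400 nM in this assay. Compound 2 `CCN(CC)CCn1cnnc1-c1cc(Oc2ccc(NC(=O)Nc3cccc(C(F)(F)F)c3)cc2F)ccn1` gives 6920 nM in this assay, and compound 3 `CN(C)CCCn1cnnc1-c1cc(Oc2ccc(NC(=O)Nc3cccc(C(F)(F)F)c3)cc2F)ccn1` gives 11600 nM in this assay. Compound 3 holds the second highest of the three numbers, within the scatter of both neighbours: a 1.7-fold higher number from compound 2 to compound 3 (0.22 log units; within the scatter), and a 1.9-fold lower number from compound 1 to compound 3 (0.29 log units; within the scatter). Going by the values given here, only one step, a 3.2-fold lower number from compound 1 to compound 2 (0.51 log units; beyond the scatter), is beyond the scatter, and all three steps concern the group attached to the aromatic carbon of the shared core, not the group on the amide-type nitrogen.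

Compound 4 `CN(C)CCCn1cnnc1-c1cc(Oc2ccc(NC(=O)Nc3ccc(Cl)cc3Cl)cc2F)ccn1` differs from compound 3 at that other end: 2,4-dichlorophenyl in place of 3-(trifluoromethyl)phenyl on an amide-type nitrogen. Among the compounds with values here, no measured step touches this position, so the data give no direct guide to its size or direction. In the absence of such a step, compound 4 is expected to stay close to compound 3 in this assay, the expected step being a 1.1-fold lower number from compound 3 to compound 4 (0.02 log units; within the scatter). The estimate for compound 4 is 11000 nM, with a range from 3500 nM to 35000 nM.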

Compound 4, half-maximal inhibitory concentration: 3260 nM
The estimate for compound 4 lay 3.4-fold (0.53 log units) above the measured number; measured number outside the range, below it.
By their numbers in this assay, from the lowest: compound 4; then compounds 2, 3 and 1 (each within the scatter of the next, the first and the last beyond it).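

In this assay, the change from 3-(trifluoromethyl)phenyl to 2,4-dichlorophenyl on the amide-type nitrogen gives a 3.6-fold lower number from compound 3 to compound 4 (0.55 log units; beyond the scatter), and this lies beyond the scatter. The earlier steps shown here all concerned the group on the aromatic carbon of the shared core, so they could not show that the aryl group at this other end also shifts the number. Nothing available explains why this exchange lowers the number.

The compounds shown leave open whether a single chlorine, as in 2-chlorophenyl or 4-chlorophenyl, would account for the step, or how an unsubstituted phenyl would compare. They also leave open whether 2,4-dichlorophenyl would lower the number to a similar extent when paired with the diethylaminoethyl chain of compound 2 or the methyl group of compound 1.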